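One Methoxy Fewer: Expecting Compound 4 in Cytotoxicity

The compounds below may be only part of what the source reports. "The series", "measured", "known", "first", "only" and "open" are said of these compounds alone.

Of the compounds shown here, three have been measured in a functional assay on SK-MEL-5 cells (Homo sapiens) for cytotoxicity, read by sulforhodamine B assay, with a stated time of 48 h, tested at 0.1 uM; a higher number here means a weaker effect of the compound at the concentration tested, a lower number a stronger effect. Compound 1, `COc1ccc(-c2cc(/C=C/C(=O)c3ccc(N)cc3)[nH]n2)cc1`, gives 90%; compound 2, `COc1cc(-c2cc(/C=C/C(=O)c3ccc(N)cc3)[nH]n2)cc(OC)c1OC`, gives 95%; and compound 3, `COc1ccc(C(=O)/C=C/c2cc(-c3cc(OC)c(OC)c(OC)c3)n[nH]2)cc1`, gives 99%. Compound 2 stands second highest of these three numbers, with compound 3 nearest and compound 1 furthest, and both of those gaps lie within the usual scatter of this kind of measurement. Among the measured compounds shown here, the only measured step that changes a single place, a number 4 percentage points higher from compound 2 to compound 3 (within the scatter), is also within the scatter, and it concerns a different part of the molecule than the change considered here.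

Compound 4, `COc1ccc(-c2cc(/C=C/C(=O)c3ccc(N)cc3)[nH]n2)cc1OC`, differs from compound 2 as follows: hydrogen in place of methoxy on an aromatic carbon. Compound 1 and compound 2 differ in how many methoxy groups they carry, yet their numbers lie within the scatter of each other, so a change in the number of methoxy groups has so far produced no visible effect. The step of a number 2 percentage points lower from compound 2 to compound 4 (within the scatter) is therefore expected to stay within the scatter. Compound 4 is estimated at 93%, between 80% and 102%.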

Compound 4, a percentage reported as activity, at one concentration (the size of the read-out at that concentration, not a potency): 95%
Compound 4: middle estimate off by 2 percentage points, on the low side, within the range that was stated.
By their numbers in this assay, from the lowest: compounds 1, 2, 4 and 3 (each within the scatter of the next).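

In this assay, hydrogen can stand in place of the methoxy group on this aromatic carbon, ortho to a methoxy group and meta to a large group, with no change at the digits printed from compound 2 to compound 4 (within the scatter) as the result. Seen from the other side, one further methoxy group gives a number 5 percentage points higher from compound 1 to compound 4 (within the scatter) as its step, so neither single change separates its pair of compounds at this one concentration. Nothing available here offers an explanation for this result.

Still open, as far as these compounds go, is whether a hydroxy group, a chlorine atom or a longer chain such as ethoxy on this same carbon would give a step beyond the scatter. A single concentration also leaves open whether compound 2 and compound 4 would still match at other concentrations.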